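The compounds below may be only part of what the source reports. "The series", "measured", "known", "first", "only" and "open" are said of these compounds alone.

Measured compounds in a functional assay on HepG2 cells (Homo sapiens) for inhibition, read by MTT assay, with a stated time of 48 h; on this read-out higher numbers stand for weaker inhibition and lower numbers for stronger inhibition:
- compound 1 `O=C(CSc1nnc(-c2ccncc2)n1-c1ccccc1)N/N=C/c1ccccc1`: 18600 nM
- compound 2 `O=C(CSc1nnc(-c2ccncc2)n1-c1ccccc1)N/N=C/c1ccc(Cl)cc1`: 11000 nM
- compound 3 `O=C(CSc1nnc(-c2ccncc2)n1-c1ccccc1)N/N=C/c1cccc(F)c1`: 24400 nM

Compound 3 gives the highest number of the three. The three steps among these compounds are a 1.3-fold higher number from compound 1 to compound 3 (0.12 log units; within the scatter), a 2.2-fold higher number from compound 2 to compound 3 (0.35 log units; beyond the scatter) and a 1.7-fold lower number from compound 1 to compound 2 (0.23 log units; within the scatter). All three compounds share the same core and differ only in the aryl group on the carbon with a double bond to nitrogen.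

Compound 4 `O=C(CSc1nnc(-c2ccncc2)n1-c1ccccc1)N/N=C/c1cc(Br)ccc1O` continues this variation: 5-bromo-2-hydroxyphenyl in place of 3-fluorophenyl on a carbon with a double bond to nitrogen. Within the data shown here, the steps that bear on it are those changing the same aryl group, namely the ones from compound 1 to compound 2, from compound 1 to compound 3 and from compound 2 to compound 3. Two of these lie within the scatter and one is modest, so a large shift in this assay is not expected. Compound 2, the only aryl variant carrying a heavier halogen, gave the lowest number, which weakly points downward from compound 3. For compound 4 a step of a 1.6-fold lower number from compound 3 to compound 4 (0.21 log units; within the scatter) is therefore expected, giving an estimated value of 15000 nM with a range of 5000 nM to 45000 nM.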

Compound 4, half-maximal inhibitory concentration: 4390 nM
Beside the measured number, compound 4's estimate is 3.4-fold (0.53 log units) above it, outside the stated range (below it).
By their numbers in this assay, from the lowest: compound 4; then compounds 2, 1 and 3 (each within the scatter of the next, the first and the last beyond it).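

In this assay the aryl group on the carbon with a double bond to nitrogen proves able to move the number beyond what the halogen swaps alone showed: 5-bromo-2-hydroxyphenyl gives a 5.6-fold lower number from compound 3 to compound 4 (0.74 log units; beyond the scatter) and a 4.2-fold lower number from compound 1 to compound 4 (0.63 log units; beyond the scatter) and also a 2.5-fold lower number from compound 2 to compound 4 (0.40 log units; beyond the scatter) as its steps. Among these compounds, compound 4 is thus the only compound of the four whose steps to all the others lie beyond the scatter, and it gives the strongest inhibition of the set. No measurement bears on why this change acts as it does.

The entering group brings bromine and a hydroxy group together, so the compounds shown cannot assign the step to either one. As far as these compounds go, how an amine or a carboxylic acid in place of that hydroxy group would read also stays open.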